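Swapping bromo for nitro on the anilide of compound 1

The compounds below may be only part of what the source reports. "The series", "measured", "known", "first", "only" and "open" are said of these compounds alone.

Compound 1 `O=C(COc1ccc2cc(/C=C3/SC(=O)NC3=O)ccc2c1)Nc1ccc(Br)cc1` — 2900 nM
Compound 2 `O=C(COc1ccc2cc(/C=C3/SC(=O)NC3=O)ccc2c1)Nc1cc(Cl)cc(C(F)(F)F)c1` — 4000 nM
Compound 3 `O=C(COc1ccc2cc(/C=C3/SC(=O)NC3=O)ccc2c1)Nc1ccccc1` — 2100 nM

Three measured compounds share one core and differ only in the aryl group on the amide-type nitrogen. In an assay on isolated protein for inhibition of histone deacetylase 4 (Homo sapiens), with a stated time of 1 h (a lower number here means a stronger inhibitor, a higher number a weaker inhibitor), compound 1 gives 2900 nM, the second highest of the three numbers. Its nearest neighbour is compound 2, with a 1.4-fold higher number from compound 1 to compound 2 (0.14 log units; within the scatter), and the furthest is compound 3, with a 1.4-fold lower number from compound 1 to compound 3 (0.14 log units; within the scatter). Between the other two the step is a 1.9-fold lower number from compound 2 to compound 3 (0.28 log units; within the scatter). Every step among these three therefore stays within the scatter, and no compound can be called stronger or weaker than another.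

Compound 4 `O=C(COc1ccc2cc(/C=C3/SC(=O)NC3=O)ccc2c1)Nc1ccc([N+](=O)[O-])cc1` has not yet been measured. It differs from compound 1 as follows: nitro in place of bromo on an aromatic carbon. Among the compounds with values here, the steps that bear on this change are those in which the aryl group on the amide-type nitrogen was altered, namely a 1.4-fold higher number from compound 1 to compound 2 (0.14 log units; within the scatter), a 1.4-fold lower number from compound 1 to compound 3 (0.14 log units; within the scatter) and a 1.9-fold lower number from compound 2 to compound 3 (0.28 log units; within the scatter). None of them moved beyond the scatter, whether bromo left, a hydrogen entered, or the aryl group was exchanged altogether. The measured compounds contain no nitro group, so there is no direct guide for it. The expectation in this assay is therefore a step of no change at the digits printed from compound 1 to compound 4 (within the scatter), not beyond the scatter. The estimate for compound 4 is 2900 nM, with a range from 1200 nM to 7000 nM.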

Compound 4, half-maximal inhibitory concentration: 1700 nM
Estimate against measurement, compound 4: 1.7-fold (0.23 log units) above, within the range that was stated.
By their numbers in this assay, from the lowest: compounds 4, 3, 1 and 2 (each within the scatter of the next, the first and the last beyond it).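

At the aromatic carbon para to a large group, nitro brings three heavy atoms and two hydrogen-bond acceptors where bromo brought one heavy atom and no acceptor, yet this assay gives a 1.7-fold lower number from compound 1 to compound 4 (0.23 log units; within the scatter) and, with hydrogen as the reference, a 1.2-fold lower number from compound 3 to compound 4 (0.09 log units; within the scatter) for this change. The earlier compounds had shown only that bromo, hydrogen and the 3-chloro-5-(trifluoromethyl)phenyl group could not be told apart; compound 4 adds that a larger group with hydrogen-bond acceptors at this position also stays within the scatter of compound 1 and compound 3, while the exchange of the whole aryl group gives a 2.4-fold lower number from compound 2 to compound 4 (0.37 log units; beyond the scatter) as the first step in the set to pass beyond the scatter, and only modestly. No measurement accompanying these compounds accounts for either result.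

On these data alone, whether an amine or a carboxylic acid on the same aromatic carbon would also stay within the scatter of compound 1 remains open. So does whether nitro on a different carbon of that ring would give a number like that of compound 4, since every compound here with a single substituent on the anilide carries it at this one place.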